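A few compounds are considered here, and "the series" means these few. Any claim that something is new, unique, unknown or untested is made for them only; others in the source may bear on it.

Measured compounds:
- Compound 1, `Oc1ccccc1CNc1ccccc1`, in a functional assay on Jurkat cells (Homo sapiens) for activation, with a stated time of 24 h; on this read-out higher numbers stand for an effect only at larger amounts of compound and lower numbers for an effect already at smaller amounts: "not active" (no number reported)
- Compound 2, `Oc1ccccc1CNc1ccc(-c2ccc(Cl)cc2)cc1`, in this assay: 2390 nM
- Compound 3, `Oc1ccccc1CNc1ccc(-c2ccc(-c3ccccc3)cc2)cc1`, in this assay: "not active" (no number reported)

Compound 3 stands without a number: in this assay compound 3 was reported as "not active" (no number reported), so no concentration can be placed against it. Compound 1 is in the same position, with "not active" (no number reported) and no number. For the measured compounds named here, only compound 2 carries a value, 2390 nM, and with two of three results lacking a number, no step between measured compounds can be drawn.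

Compound 4, `Oc1ccc(-c2ccc(NCc3ccccc3O)cc2)cc1`, arises from compound 3 by one change: hydroxy in place of phenyl on an aromatic carbon. No step size for this change is known from the measured compounds, so the expected size and direction cannot be read from a comparison. Compound 4 keeps the two-ring arrangement with a single small group at the far end, and compound 2, which is built the same way, gave 2390 nM, so compound 4 is expected to fall in that neighbourhood rather than to stay without a number. The estimate for compound 4 in this assay is 3500 nM, expected within 800 nM to 15000 nM, with a real chance that only no number is reported.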

Compound 4, half-maximal effective concentration: "not active" (no number reported)
The entry for compound 4 holds no number; the estimate stays without a comparison.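

No new step can be read: compound 3 gives "not active" (no number reported) and compound 4 gives "not active" (no number reported), so replacing phenyl with hydroxy has no measurable size here. No evidence is available to explain this result. The compounds shown leave open why compound 2 alone carries a value, 2390 nM, among these compounds.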